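The source may report more compounds than this note shows. Statements on the series, on what has been measured and on what is new or still open speak of the compounds shown alone.

Measured so far in a functional assay on aorta for antagonist activity at Alpha-1D adrenergic receptor (Rattus norvegicus); a higher number here means weaker binding, a lower number tighter binding:
compound 1, `CN(C)C(=O)c1cccnc1NCCCN1CCN(c2ccccc2C#N)CC1`: 10 nM
compound 2, `Cc1ccccc1N1CCN(CCCNc2ncccc2C(=O)N(C)C)CC1`: 10 nM
compound 3, `COc1cc(F)ccc1N1CCN(CCCNc2c(C(=O)N(C)C)cnc3c(C)cccc23)CC1`: 316 nM

Compound 2 and compound 1 share a core and differ by cyano in place of methyl on an aromatic carbon. In this assay this gave no change at the digits printed from compound 2 to compound 1 (within the scatter). Compound 3 rests on a different core, and the difference between the two cores is not broken down here; its value in this assay stands well apart from both compound 1 and compound 2, as their numbers show.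

Compound 4, `COc1cc(F)ccc1N1CCN(CCCNc2c(C(=O)N(C)C)cnc3c(C#N)cccc23)CC1`, has not been measured. It differs from compound 3 by cyano in place of methyl on an aromatic carbon. This is the same kind of change as that from compound 2 to compound 1, but not the same: in compound 3 the aromatic carbon is part of a fused or bridged system of two rings, ortho to a fused ring and meta to a fused ring, whereas in compound 2 it is ortho to a large group. Since the earlier step was no change at the digits printed from compound 2 to compound 1 (within the scatter), a step of a 1.1-fold lower number from compound 3 to compound 4 (0.02 log units; within the scatter) is expected from compound 3 to compound 4 in this assay, with a wide margin for the different surroundings. Compound 4 is therefore estimated at 300 nM, between 90 nM and 1000 nM.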

Compound 4, dissociation constant: 398 nM
Compound 4: middle estimate off by 1.3-fold (0.12 log units), on the low side; the measured number falls inside the stated range.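

In this assay, cyano in place of methyl on an aromatic carbon gave a 1.3-fold higher number from compound 3 to compound 4 (0.10 log units; within the scatter). Set beside the earlier case, the change gave the same outcome on both cores, one with numbers far lower in this assay than the other: the same change on two cores in this assay, no change at the digits printed (within the scatter) from compound 2 to compound 1 and a 1.3-fold higher number (0.10 log units; within the scatter) from compound 3 to compound 4, 1.3-fold (0.10 log units) apart, within the scatter of two such steps. This shows that, for these two pairs, the swap could be carried from one core to the other without a step beyond the scatter; it does not show that the same would hold on a third core, at another place on these rings, or in another assay, and it does not break down the difference between the two cores.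

The compounds shown leave open whether other groups on this aromatic carbon, such as a chlorine atom, a methoxy group or an amine, would behave as cyano and methyl do here. They also leave open how a longer chain, or a carboxylic acid in place of the amide, would change the numbers on either core.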